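The compounds below may be only part of what the source reports. "The series", "measured", "known", "first", "only" and "open" are said of these compounds alone.

Three members of this series carry the shared core with a substituted phenyl on the aromatic-ring nitrogen. Compound 1 `C=CC(=O)Nc1cccc(NC(=O)CSc2nc(Nc3ccc(CC)cc3)c3ccccc3n2)c1` gives 14400 nM in a functional assay on MDA-MB-231 cells (Homo sapiens) for inhibition, read by MTT assay, with a stated time of 72 h; on this read-out lower numbers stand for stronger inhibition and higher numbers for weaker inhibition. Compound 2 `C=CC(=O)Nc1cccc(NC(=O)CSc2nc(Nc3ccc(Cl)c(Cl)c3)c3ccccc3n2)c1` gives 17700 nM in this assay, and compound 3 `C=CC(=O)Nc1cccc(NC(=O)CSc2nc(Nc3ccc(F)c(Cl)c3)c3ccccc3n2)c1` gives 10600 nM. Compound 3 holds the lowest of the three numbers, yet its gaps to both of the others stay within the scatter, so no order among them can be read from the data. The next member, compound 4 `C=CC(=O)Nc1cccc(NC(=O)CSc2nc(Nc3ccc(Cl)cc3Cl)c3ccccc3n2)c1`, differs from compound 3 by 2,4-dichlorophenyl in place of 3-chloro-4-fluorophenyl on a nitrogen on an aromatic ring. Within the data shown here, three measured steps bear on such exchanges of the substituted phenyl: a 1.2-fold higher number from compound 1 to compound 2 (0.09 log units; within the scatter), a 1.4-fold lower number from compound 1 to compound 3 (0.13 log units; within the scatter) and a 1.7-fold lower number from compound 2 to compound 3 (0.22 log units; within the scatter). Each of them lies within the scatter, so swapping one substituted phenyl for another has so far moved this assay by no more than a repeated measurement would. A further rearrangement of the two chlorines on the phenyl is therefore expected to give no step beyond the scatter, the expected step being a 1.2-fold higher number from compound 3 to compound 4 (0.09 log units; within the scatter). Compound 4 is accordingly estimated at 13000 nM in this assay, with a range from 6000 nM to 30000 nM.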

Compound 4, half-maximal inhibitory concentration: 23100 nM
Compound 4: the middle estimate sits 1.8-fold (0.25 log units) below what was measured; low and high end bracket the measured number.
By their numbers in this assay, from the lowest: compounds 3, 1, 2 and 4 (each within the scatter of the next, the first and the last beyond it).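

At the nitrogen on an aromatic ring, the phenyl exchange in this assay now gives its first step beyond the scatter, though a modest one (a 2.2-fold higher number from compound 3 to compound 4 (0.34 log units; beyond the scatter)), so changing this substituent can move the number by more than a repeated measurement would. The separation is limited to this one pair: the exchange of 3,4-dichlorophenyl for 2,4-dichlorophenyl stays within the scatter (a 1.3-fold higher number from compound 2 to compound 4 (0.12 log units; within the scatter)), as does the exchange of 4-ethylphenyl for 2,4-dichlorophenyl (a 1.6-fold higher number from compound 1 to compound 4 (0.21 log units; within the scatter)), so the two dichlorophenyl arrangements cannot be told apart here. No supporting measurement is at hand to account for the step from 3-chloro-4-fluorophenyl to 2,4-dichlorophenyl.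

The four compounds leave open whether a phenyl bearing a carboxylic acid, a dimethylamino group or a longer alkyl chain would shift the number well outside the range seen with these halogen and ethyl substituents. They also leave open how changes elsewhere would read in this assay, as the rest of the shared core stays the same throughout.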